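Propargyloxy in place of methoxy on the shared core

This account rests on a few compounds, and the source may have more. Where it says the series, first, only, none or still open, it means among the compounds named here.

Measured so far in a functional assay on A549 cells (Homo sapiens) for inhibition, read by sulforhodamine B assay, with a stated time of 48 h, tested at 50 uM; a higher number here means more inhibition of growth at the concentration tested, a lower number less inhibition of growth:
compound 1 `COc1ccc([C@@H]2CC(=O)c3cc(CC=C(C)C)c(OC)cc3O2)cc1` gives 45%
compound 2 `COc1ccc([C@@H]2C/C(=N/OCc3cn(-c4ccc(C#N)cc4)nn3)c3cc(CC=C(C)C)c(OC)cc3O2)cc1` gives 42%

For the measured compounds named here, compound 1 and compound 2 lie within the scatter of each other, so compound 1 does not separate from the only other measured compound. Compound 3 `C#CCOc1ccc([C@@H]2CC(=O)c3cc(CC=C(C)C)c(OC)cc3O2)cc1` keeps the core of compound 1 and turns methoxy to propargyloxy, with ethynyl in place of hydrogen on a saturated chain carbon bound to an oxygen on an aromatic ring. Going by the values given here, no measured pair isolates a single change, so the size of this step has no direct precedent. In this assay the expectation is no shift beyond the scatter, in either direction. Structurally further from compound 1, compound 2 still gives 42%, which fits that expectation. The expected change is a number 1 percentage points lower from compound 1 to compound 3 (within the scatter). The estimate for compound 3 is 44%, with an expected range of 28% to 60%.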

Compound 3, percent growth inhibition at one concentration: 53%
Beside the measured number, compound 3's estimate is 9 percentage points below it; measured number inside the range.
By their numbers in this assay, from the lowest: compounds 2, 1 and 3 (each within the scatter of the next, the first and the last beyond it).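

Methoxy to propargyloxy is the only change in the series isolated in one place, and in this assay it reads as a number 8 percentage points higher from compound 1 to compound 3 (within the scatter). Ethynyl in place of hydrogen on this saturated chain carbon bound to an oxygen on an aromatic ring therefore gives no separable change in growth inhibition at the concentration tested, so this position accepts the propargyl group with the rest of the core of compound 1 unchanged. Nothing available bears on why the step reads this way.

The compounds shown leave open whether any larger group at this place would be accepted in the same way, since a single step cannot define the limits of the position. A propoxy group would separate the triple bond from the chain length, and a carboxylic acid or an amine at the end of the chain would test a quite different end group.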